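From Methyl to Amino on the Shared Core

A few compounds are considered here, and "the series" means these few. Any claim that something is new, unique, unknown or untested is made for them only; others in the source may bear on it.

Among the compounds with values here, in a functional assay on HeLa cells (Homo sapiens) for antiproliferative activity, read by MTT assay, with a stated time of 48 h (on this read-out higher numbers stand for weaker inhibition and lower numbers for stronger inhibition), compound 1 `COc1ccc(-c2cc3c(cn2)[nH]c(=O)n3-c2cc(OC)c(OC)c(OC)c2)cc1F` gives 2210 nM and compound 2 `COc1ccc(-c2cc3c(cn2)[nH]c(=O)n3-c2cc(OC)c(OC)c(OC)c2)cc1C` gives 1410 nM, so compound 2 stands within the scatter of its only neighbour. Compound 3 `COc1ccc(-c2cc3c(cn2)[nH]c(=O)n3-c2cc(OC)c(OC)c(OC)c2)cc1N` follows from compound 2 through (amino in place of methyl on an aromatic carbon), amino in place of methyl on an aromatic carbon. Within the data shown here, only one measured step bears on this change: a 1.6-fold lower number from compound 1 to compound 2 (0.20 log units; within the scatter), methyl in place of fluoro on that same carbon, and it stays within the scatter. Among the measured compounds shown here, no amino compound has been measured, so no step beyond the scatter is expected in this assay, in either direction, though uncertainty remains wide. For compound 3, the estimated value is 1000 nM, with an expected range from 250 nM to 3000 nM.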

Compound 3, half-maximal inhibitory concentration: 770 nM
Compound 3: the middle estimate sits 1.3-fold (0.11 log units) above what was measured, and the stated range covers the measured number.
By their numbers in this assay, from the lowest: compounds 3, 2 and 1 (each within the scatter of the next, the first and the last beyond it).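

Against fluoro, the amino group gives the first step at this carbon in this assay to pass the scatter, though a modest one (a 2.9-fold lower number from compound 1 to compound 3 (0.46 log units; beyond the scatter)). Against methyl it does not (a 1.8-fold lower number from compound 2 to compound 3 (0.26 log units; within the scatter)). Methyl thus stays within the scatter of both neighbours, so only compound 1 and compound 3 can be told apart, and a hydrogen-bond donor count of 1 in the entering amino group comes with no separable effect.

From the compounds shown here alone, whether a methylamino, dimethylamino or hydroxyl group on this carbon would reach beyond compound 3 stays open. Nothing at hand accounts for the separation of compound 3 from compound 1.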